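Swapping Chloro for Bromo in Compound 3

This account rests on a few compounds, and the source may have more. Where it says the series, first, only, none or still open, it means among the compounds named here.

Compound 1 `COc1ccc(S(=O)(=O)n2c(-c3cn(-c4ccccc4)nc3-c3ccc(C(F)(F)F)cc3)nc3ccccc32)cc1` gives 170 nM
Compound 2 `O=[N+]([O-])c1ccc(S(=O)(=O)n2c(-c3cn(-c4ccccc4)nc3-c3ccc(C(F)(F)F)cc3)nc3ccccc32)cc1` gives 790 nM
Compound 3 `O=S(=O)(c1ccc(Cl)cc1)n1c(-c2cn(-c3ccccc3)nc2-c2ccc(C(F)(F)F)cc2)nc2ccccc21` gives 2560 nM

These three values come from a functional assay on A549 cells (Homo sapiens) for antiproliferative activity, read by MTT assay, with a stated time of 24 h; on this read-out lower numbers stand for stronger inhibition and higher numbers for weaker inhibition. Compound 3 has the highest number of the three, so it is the weakest inhibitor so far. Compound 4 `O=S(=O)(c1ccc(Br)cc1)n1c(-c2cn(-c3ccccc3)nc2-c2ccc(C(F)(F)F)cc2)nc2ccccc21` has not yet been measured. It differs from compound 3 in a single place: bromo in place of chloro on an aromatic carbon. This is bromo in place of chloro on an aromatic carbon, para to a large group.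

The measured steps all change the group at this same place. One is modest, a 3.2-fold higher number from compound 2 to compound 3 (0.51 log units; beyond the scatter), and another is large, a 15-fold higher number from compound 1 to compound 3 (1.18 log units; beyond the scatter). The third is also modest, a 4.6-fold higher number from compound 1 to compound 2 (0.67 log units; beyond the scatter). So this place can clearly shift the number, but no measured step replaces chloro with bromo, and neither methoxy nor nitro is a close model for that swap. A step within the scatter is therefore expected in this assay, with no favoured direction. The expected step is a 1.2-fold lower number from compound 3 to compound 4 (0.07 log units; within the scatter). For compound 4 the estimate is 2200 nM, with an expected range of 800 nM to 6000 nM.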

Compound 4, half-maximal inhibitory concentration: 1690 nM
For compound 4 the middle estimate is 1.3-fold (0.11 log units) above the measured one; the range from low to high includes it.
By their numbers in this assay, from the lowest: compound 1; then compound 2; then compounds 4 and 3 (each within the scatter of the next).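

In this assay the swap of chloro for bromo gives a 1.5-fold lower number from compound 3 to compound 4 (0.18 log units; within the scatter) and so the two halogens cannot be told apart at this place. Bromo stays clear of the other two groups, with a 2.1-fold higher number from compound 2 to compound 4 (0.33 log units; beyond the scatter) and a 9.9-fold higher number from compound 1 to compound 4 (1.00 log units; beyond the scatter) on the same side as chloro, so across these four compounds the position separates methoxy and nitro from the halogens, not one halogen from the other. Nothing available explains why chloro and bromo fall together or why methoxy gives the lowest number.

Going by these compounds, whether fluoro would fall with chloro and bromo remains open, as does what an amine, a carboxylic acid or a longer chain would do here. These compounds vary only this one place, so it is also unknown whether the same grouping would hold with a different group elsewhere on the shared core.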